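Moving a trifluoromethyl group around a phenyl ring

The source may report more compounds than this note shows. Statements on the series, on what has been measured and on what is new or still open speak of the compounds shown alone.

Two compounds have been measured in a functional assay on CHO cells for agonist activity at Free fatty acid receptor 1 (Homo sapiens), read by FLIPR and calcium flux, tested at 100 nM; on this read-out higher numbers stand for a stronger effect at the one concentration tested and lower numbers for a weaker effect:

compound 1, `Cc1ccccc1-c1nc(C)c(COc2ccc3c(c2)OCC3CC(=O)O)s1`, gives 10.7%
compound 2, `Cc1nc(-c2ccccc2C(F)(F)F)sc1COc1ccc2c(c1)OCC2CC(=O)O`, gives 7.76%

For the measured compounds named here, the only measured step joins these two: a number 2.9 percentage points lower from compound 1 to compound 2 (within the scatter). Compound 2 thus holds the lower of the two numbers, with compound 1 the nearest neighbour, and the gap between them lies within the scatter, so no order can be read from it.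

Compound 3, `Cc1nc(-c2ccc(C(F)(F)F)cc2)sc1COc1ccc2c(c1)OCC2CC(=O)O`, has not yet been measured. Its structure differs from compound 2 in a single way: 4-(trifluoromethyl)phenyl in place of 2-(trifluoromethyl)phenyl on an aromatic carbon. Going by the values given here, no measured step describes a change of this kind; the one step recorded concerns a trifluoromethyl in place of methyl, and it was within the scatter. There is therefore nothing in the data that points to a shift in either direction, and the expectation is that compound 3 will sit close to compound 2 in this assay.

On that basis compound 3 is estimated to give 9%, with a range from 0% to 22%. The expected step from compound 2 to compound 3 is a number 1.2 percentage points higher from compound 2 to compound 3 (within the scatter), which is none beyond the scatter.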

Compound 3, a percentage reported as activity, at one concentration (the size of the read-out at that concentration, not a potency): 50.4%
For compound 3 the middle estimate is 41.4 percentage points below the measured one; the whole stated range lies below it.
By their numbers in this assay, from the lowest: compounds 2 and 1 (each within the scatter of the next); then compound 3.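

In this assay, 2-methylphenyl and 2-(trifluoromethyl)phenyl had stayed within the scatter of each other, which said nothing about where on the phenyl ring a group might count. With the same atoms joined differently, 4-(trifluoromethyl)phenyl in place of 2-(trifluoromethyl)phenyl gives a number 42.6 percentage points higher from compound 2 to compound 3 (beyond the scatter) at this aromatic carbon of the five-membered ring, so the place of the trifluoromethyl on the phenyl ring matters here, and not only the choice between trifluoromethyl and methyl. Set against 2-methylphenyl, the same group gives a number 39.7 percentage points higher from compound 1 to compound 3 (beyond the scatter) as a step of the same large kind, and nothing at hand offers a reason for the change.

The compounds shown leave open whether this rise belongs to the trifluoromethyl itself or to the place it holds in 4-(trifluoromethyl)phenyl, which a methyl, a chlorine or a methoxy group in that same place would help to settle. They also leave open how an unsubstituted phenyl compares, and, as the read-out comes from one concentration, they say nothing about potency.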